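The source may hold more compounds than are shown below. What is called first, only, known or untested is meant among the compounds shown, and "the series" means these compounds.

Measured in an assay on cells for inhibition of matrix metalloproteinase-9 (Homo sapiens), read by fluorescence, with stated times of 15 min and 4 h; a lower number here means a stronger inhibitor, a higher number a weaker inhibitor:

- compound 1, `O=C(CCCc1ccccc1)Nc1ccc(-c2nc3ccc(Br)cc3[nH]2)cc1`: 58000 nM
- compound 2, `O=C(CCc1ccccc1)Nc1ccc(-c2nc3ccccc3[nH]2)cc1`: 29000 nM
- compound 3, `O=[N+]([O-])c1cccc(-c2nc3ccc(Br)cc3[nH]2)c1`: a limit, > 100000 nM

Compound 3 stands apart from the other two in that it gives no number in this assay but only a limit, (the limit of > 100000 nM in this assay, at which 1 of the 3 values shown sits). Compounds 1 and 2 both give numbers, so compound 3 is the one of the three whose inhibition falls outside the measured range.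

Compound 4, `Cc1ccc2nc(-c3cccc([N+](=O)[O-])c3)[nH]c2c1`, differs from compound 3 in one place: methyl in place of bromo on an aromatic carbon of the six-membered ring of carbon only, part of a fused or bridged system of two rings. Within the data shown here, no measured step of this kind is available, and the starting point is itself a limit. The expectation is that the exchange of bromo for methyl brings no step beyond the scatter in this assay, so that compound 4 is expected to remain at or near the limit; the expected step from compound 3 to compound 4 is a number no higher from compound 3 to compound 4 (the limit leaves the size open). The estimate for compound 4 in this assay is 100000 nM, with a range from 30000 nM to 300000 nM, and it is expected that this assay may again report only a limit for compound 4.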

Compound 4, half-maximal inhibitory concentration: 36600 nM
The estimate for compound 4 lay 2.7-fold (0.44 log units) above the measured number, within the range that was stated.
By their numbers in this assay, from the lowest: compounds 2, 4 and 1 (each within the scatter of the next). At a limit, above all of these: compound 3.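

In this assay, methyl in place of bromo on an aromatic carbon of the six-membered aromatic ring gives an at least 2.7-fold lower number from compound 3 to compound 4 (0.43 log units; beyond the scatter) as the first step readable in this series. That step is only a lower bound on the change, because compound 3 stands at a limit and not at a number: the limit of > 100000 nM in this assay, at which 1 of the 4 values shown sits.
This single exchange at this position is enough to bring compound 4 into the measured range, with 36600 nM as its number.

Going by these compounds, whether the same exchange moves the number in compounds carrying the amide chain stays open, as compounds 1 and 2 differ from each other in more than one place and give no reading of it. Also open, on these data alone, is how chloro, methoxy or an amine at this position would compare with methyl and bromo.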